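Spiro-piperidine amides: chloropyridinyl amine variant

A few compounds are considered here, and "the series" means these few. Any claim that something is new, unique, unknown or untested is made for them only; others in the source may bear on it.

Compound 1 `Cc1ccc(-n2nccn2)c(C(=O)N2CCC3(CC3)C[C@H]2CNc2cccc(C)n2)c1` is one of two measured members of the series. In a functional assay on CHO cells for antagonist activity at Orexin/Hypocretin receptor type 1 (Homo sapiens), read by FLIPR and calcium flux (on this read-out lower numbers stand for lower potency and higher numbers for higher potency (the scale is a negative logarithm)), compound 1 gives 8.2. Compound 2 `Cc1nc(C(=O)N2CCC3(CC3)C[C@H]2CNc2ccc(Cl)cn2)c(-c2ccccc2)s1`, which carries a different amide aryl group, gives 7.9 in this assay, a value within the scatter of the number for compound 1, so the two show no ordered difference. Compound 3 `Cc1ccc(-n2nccn2)c(C(=O)N2CCC3(CC3)C[C@H]2CNc2ccc(Cl)cn2)c1` keeps the core of compound 1 with 5-chloropyridin-2-yl in place of 6-methylpyridin-2-yl on an amine nitrogen. Among the compounds with values here, no measured pair isolates this change; with compound 2 at 7.9 already carrying the same amine, the step is expected to stay within the scatter. For compound 3 the estimate is 8.1 (range 7.5 to 8.7), a step of a number 0.10 log units lower from compound 1 to compound 3 (within the scatter).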

Compound 3, negative logarithm of the antagonist equilibrium constant: 7.5
For compound 3 the middle estimate is 0.60 log units above the measured one, and the stated range covers the measured number.
By their numbers in this assay, from the lowest: compound 3; then compounds 2 and 1 (each within the scatter of the next).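

On an amine nitrogen of the shared core, 5-chloropyridin-2-yl in place of 6-methylpyridin-2-yl gives in this assay a number 0.70 log units lower from compound 1 to compound 3 (beyond the scatter) and so is not a neutral swap. Within the data shown here, this is the first pair that isolates this position, and it shows that the value responds to this change although the heavy-atom count stays the same. Nothing available bears on the reason for the step.

Still open, from the compounds shown here alone, is whether the step follows the chlorine or its place on the pyridine, which 6-chloropyridin-2-yl on the same nitrogen would separate. Also open, going by these compounds, is whether the step carries over to the amide aryl group of compound 2.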